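Adding chloro to the phenyl of compound 1

The compounds below may be only part of what the source reports. "The series", "measured", "known", "first", "only" and "open" are said of these compounds alone.

Compound 1 `O=C(N[C@H]1CN(S(=O)(=O)c2ccccc2)C[C@@H]1C(=O)N[C@H]1CCCNC1)c1cc(-c2ccccc2)on1` gives 13.2 mL/min/kg in an ADME assay on the whole organism (Canis lupus familiaris) for pharmacokinetics; on this read-out higher numbers stand for fast clearance and lower numbers for slow clearance. Compound 2 `Cc1nc(-c2cccc(C(F)(F)F)c2)sc1C(=O)N[C@H]1CN(S(=O)(=O)c2ccccc2)C[C@@H]1C(=O)N[C@H]1CCCNC1` gives 13 mL/min/kg, which leaves the two within the scatter of each other. Compound 3 `O=C(N[C@H]1CN(S(=O)(=O)c2ccccc2)C[C@@H]1C(=O)N[C@H]1CCCNC1)c1cc(-c2ccccc2Cl)on1` differs from compound 1 by one change: chloro in place of hydrogen on an aromatic carbon, ortho to a large group. Within the data shown here, no measured pair shows this change on its own, so no direction is favoured. The expected step in this assay is a 1.1-fold lower number from compound 1 to compound 3 (0.04 log units; within the scatter), none beyond the scatter. Compound 3 is estimated at 12 mL/min/kg, with an expected range of 6 mL/min/kg to 24 mL/min/kg.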

Compound 3, clearance: 10.5 mL/min/kg
Compound 3: the middle estimate sits 1.1-fold (0.06 log units) above what was measured, and the stated range covers the measured number.
By their numbers in this assay, from the lowest: compounds 3, 2 and 1 (each within the scatter of the next).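

Phenyl to 2-chlorophenyl gives the series its first single-place comparison: in this assay this change gives a 1.3-fold lower number from compound 1 to compound 3 (0.10 log units; within the scatter). On an aromatic carbon ortho to a large group, chloro in place of hydrogen therefore gives no shift in clearance beyond the scatter. No available evidence speaks to what underlies this result.

Still open, going by these compounds, is whether a larger or different group at the same place, such as an amine or a methoxy group, would shift clearance beyond the scatter. On these data alone, the effect of chloro at other places on this phenyl also remains open.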